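This account rests on a few compounds, and the source may have more. Where it says the series, first, only, none or still open, it means among the compounds named here.

Measured compounds:
compound 1, `COc1ccc(/C=N/NC(=O)Nc2ccc(Oc3ccnc4cc(OCCCN5CCCCC5)c(OC)cc34)c(F)c2)cc1`: 126000 nM
compound 2, `COc1cc2c(Oc3ccc(NC(=O)N/N=C/c4ccc(C(F)(F)F)cc4)cc3F)ccnc2cc1OCCCN1CCCCC1`: "not determined" (no result reported)

Compound 1 stands alone with a number in an ADME assay on PBL cells (Homo sapiens) for cytotoxicity, read by MTT assay, with a stated time of 72 h; on this read-out lower numbers stand for stronger inhibition and higher numbers for weaker inhibition. In this assay, among the measured compounds shown here, compound 1 gives 126000 nM, which is the only value available, so there is nothing to rank it against. For the measured compounds named here, for compound 2 no result was reported in this assay, and the pair therefore yields no step that could be used as a yardstick.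

Compound 3, `COc1ccc(/C=N/NC(=O)Nc2ccc(Oc3ccnc4cc(OCCCN5CCC(C)CC5)c(OC)cc34)c(F)c2)cc1`, differs from compound 1 by methyl in place of hydrogen on a saturated ring carbon, three ring bonds from the ring nitrogen. Going by the values given here, no comparison between measured compounds exists to show what such a change does in this assay.

Among the compounds with values here, with nothing to go on beyond the one value, the step from compound 1 to compound 3 is expected to stay within the scatter of repeated measurements, a 1.3-fold lower number from compound 1 to compound 3 (0.10 log units; within the scatter), with at most a slight lean toward a lower number. Compound 3 is therefore estimated at 100000 nM, with a range from 40000 nM to 250000 nM.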

Compound 3, half-maximal inhibitory concentration: 23000 nM
The estimate for compound 3 lay 4.3-fold (0.64 log units) above the measured number; measured number outside the range, below it.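

Among the compounds shown here, the change from piperidin-1-yl to 4-methylpiperidin-1-yl, methyl in place of hydrogen on a saturated ring carbon, three ring bonds from the ring nitrogen, gives the first readable comparison in this assay: a 5.5-fold lower number from compound 1 to compound 3 (0.74 log units; beyond the scatter). A single added carbon at this ring position is therefore enough to carry the number beyond the usual scatter, and it moves toward stronger inhibition of these cells, although both compounds still sit at the high values printed for them. This rests on one pair of compounds, and nothing measured alongside them speaks to why the number moves.

Going by these compounds, it remains open whether the shift belongs to methyl in particular, or whether ethyl, hydroxyl, an amine or a carboxylic acid on the same ring carbon would move the number the same way, further, or in the opposite direction. On these data alone, it is equally open whether a morpholine in place of the piperidine would matter, and whether the methyl step would hold with a different aryl group on the other side of the molecule, since compound 2 has no reported result to compare.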